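The source may report more compounds than this note shows. Statements on the series, on what has been measured and on what is new or still open speak of the compounds shown alone.

In a functional assay on SK-BR-3 cells (Homo sapiens) for antiproliferative activity (on this read-out higher numbers stand for weaker inhibition and lower numbers for stronger inhibition), compound 3, `CC(C)=CCc1cc(C(=O)Nc2cc3ccc(OCCCN(C)c4ccccc4)c(C)c3oc2=O)ccc1O`, gives > 50000 nM, which is a limit and not a number. Compound 3 therefore sits at the limit of > 50000 nM in this assay, at which 2 of the 3 values shown sit. Compound 1, `CC(C)=CCc1cc(C(=O)Nc2cc3ccc(OCCCN4CCCCC4)c(C)c3oc2=O)ccc1O`, gives > 50000 nM, which is also a limit. Among the measured compounds shown here, compound 2, `CCN(CC)CCCOc1ccc2cc(NC(=O)c3ccc(O)c(CC=C(C)C)c3)c(=O)oc2c1C`, gives 4900 nM, the only true number so far.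

Compound 4, `CC(C)=CCc1cc(C(=O)Nc2cc3ccc(OCCCN[C@@H]4C[C@H]5CC[C@@H]4C5)c(C)c3oc2=O)ccc1O`, is the next to be read. It differs from compound 3 by a group of 8 heavy atoms (7 carbon, 1 nitrogen; 2 five-membered non-aromatic rings of carbon only) in place of a group of 8 heavy atoms (7 carbon, 1 nitrogen; one six-membered aromatic ring of carbon only), on a saturated chain carbon, three bonds along the chain from an oxygen on an aromatic ring. For the measured compounds named here, no measured step makes this exact exchange, but three steps alter the same group at the same place. They are an at least 10-fold lower number from compound 1 to compound 2 (1.00 log units; beyond the scatter), an at least 10-fold higher number from compound 2 to compound 3 (1.00 log units; beyond the scatter) and a step that the two limits leave unreadable from compound 1 to compound 3. The group at this place can therefore matter a great deal, although only compound 2 has escaped the limit, and the two limits at compound 1 and compound 3 show that most of the exchanges seen so far leave no readable activity.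

A modest move toward a lower number in this assay is expected, with compound 2 at 4900 nM as the best reading that the series has given. The expected change is an at least 2.2-fold lower number from compound 3 to compound 4 (0.35 log units; beyond the scatter), and a further limit would be no surprise. For compound 4 the estimated value is 22000 nM, within an expected range from 5000 nM to 60000 nM.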

Compound 4, half-maximal inhibitory concentration: 770 nM
Estimate against measurement, compound 4: 29-fold (1.46 log units) above; the whole stated range lies above it.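

In this assay, the place on a saturated chain carbon, three bonds along the chain from an oxygen on an aromatic ring, now proves able to carry a ring-bearing group and still give a true number: the result shows an at least 64-fold lower number from compound 3 to compound 4 (1.81 log units; beyond the scatter) and an at least 64-fold lower number from compound 1 to compound 4 (1.81 log units; beyond the scatter), so a ring in this group does not by itself leave a compound at the limit. The first of these exchanges keeps the group at 8 heavy atoms (7 carbon, 1 nitrogen), so that count alone does not set the reading; what changes is one six-membered aromatic ring of carbon only giving way to 2 five-membered non-aromatic rings of carbon only, with 1 hydrogen-bond donor entering where methyl(phenyl)amino has 0. Among the compounds shown here, the new group also goes past diethylamino, the source of the only earlier true number, with a 6.4-fold lower number from compound 2 to compound 4 (0.80 log units; beyond the scatter).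

Compound 1 and compound 3 each remain at a limit and not a number, so the full size of their steps stays unknown: the limit of > 50000 nM in this assay, at which 2 of the 4 values shown sit. The compounds shown cannot separate the hydrogen-bond donor from the saturated ring frame, which a cyclohexylamino group or the entering group with a methyl on its nitrogen could address, and the role of its 3 defined stereocentres is equally open.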